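Swapping a Difluorophenylcarbonyl Cap for an Indazolylmethyl Arm

A few compounds are considered here, and "the series" means these few. Any claim that something is new, unique, unknown or untested is made for them only; others in the source may bear on it.

Measured so far:
- compound 1, `O=C(Nc1ccc(-c2cscn2)cc1)C1CCCN(C(=O)c2ccc(F)c(F)c2)C1`, gives > 20000 nM in a functional assay on A-375 cells (Homo sapiens) for antiproliferative activity (on this read-out lower numbers stand for stronger inhibition and higher numbers for weaker inhibition), which is a limit of the assay rather than a number.
- compound 2, `O=C(NC1CCCN(Cc2ccc(F)c(F)c2)C1)c1ccc(-c2cscn2)cc1`, gives > 20000 nM in this assay, again only a limit.
- compound 3, `O=C(Nc1ccc(-c2cscn2)cc1)[C@@H]1CCCN(Cc2ccc(F)c(F)c2)C1`, gives 6000 nM in this assay.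

Compound 1 therefore stands at the limit of the assay, and it shares that position with one other compound, as the limit of > 20000 nM in this assay, at which 2 of the 3 values shown sit, shows. Only compound 3 gives a number at all, so compound 1 lies at the weak end of what has been seen.

Compound 4, `O=C(Nc1ccc(-c2cscn2)cc1)C1CCCN(Cc2ccc3cn[nH]c3c2)C1`, differs from compound 1 in one place: (1H-indazol-6-yl)methyl in place of (3,4-difluorophenyl)carbonyl on an amine nitrogen in a ring. In this assay, among the compounds with values here, compound 1 gave only a limit, so no measured step tells how far this change can move the value. Compound 3 shows that a compound of this core can reach a measurable number once the group on the ring nitrogen is changed; the change here is of the same kind. Compound 4 is therefore expected to show stronger inhibition than compound 1, a step of an at least 4.0-fold lower number from compound 1 to compound 4 (0.60 log units; beyond the scatter) that should go beyond the usual scatter. The estimate for compound 4 is 5000 nM, within a range from 1000 nM to 20000 nM.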

Compound 4, half-maximal inhibitory concentration: > 20000 nM
Compound 4: a limit, no number (the forecaster's own chance of this, stated with the estimate: 30%); at least 4.0-fold (0.60 log units) between middle value and limit.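

Within the data shown here, compound 1 and compound 4 both give only a limit, not a number, in this assay, so no step between them can be read: the limit of > 20000 nM in this assay, at which 3 of the 4 values shown sit.

The compounds shown leave open whether (1H-indazol-6-yl)methyl in place of (3,4-difluorophenyl)carbonyl moves the value in either direction.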